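A few compounds are considered here, and "the series" means these few. Any claim that something is new, unique, unknown or untested is made for them only; others in the source may bear on it.

In a functional assay on SW-620 cells (Homo sapiens) for cytotoxicity, read by MTT assay, with a stated time of 72 h (a lower number here means a stronger inhibitor, a higher number a weaker inhibitor), compound 3 `COc1ccc(/C=C2\CCC/C(=C\c3cccc(Br)c3)C2=O)cc1OC` gives 4200 nM, the lowest of the three numbers recorded. Compound 1 `COc1cccc(/C=C2\CCC/C(=C\c3cccc(OC)c3OC)C2=O)c1` gives 7000 nM, which stands within the scatter of compound 3, while compound 2 `COc1cc(/C=C2\CCC/C(=C\c3cccc(OC)c3OC)C2=O)ccc1O` gives 8600 nM, a gap to compound 3 that lies beyond it. For the measured compounds named here, the only measured step, a 1.2-fold higher number from compound 1 to compound 2 (0.09 log units; within the scatter), concerns the other aryl ring and does not bear on the change to compound 4 `COc1ccc(/C=C2\CCC/C(=C\c3cc(Cl)cc(Cl)c3)C2=O)cc1OC`, which is 3,5-dichlorophenyl in place of 3-bromophenyl on a double-bonded chain carbon bound to a double-bonded ring carbon. Going by the values given here, with no step touching this ring, the expectation is that compound 4 stays within the scatter of compound 3, so the estimated step is a 1.1-fold lower number from compound 3 to compound 4 (0.02 log units; within the scatter). Compound 4 is therefore expected to give 4000 nM, with a range from 1500 nM to 11000 nM.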

Compound 4, half-maximal inhibitory concentration: 2500 nM
Estimate against measurement, compound 4: 1.6-fold (0.20 log units) above, within the range that was stated.
By their numbers in this assay, from the lowest: compounds 4, 3, 1 and 2 (each within the scatter of the next, the first and the last beyond it).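

In this assay the swap gives a 1.7-fold lower number from compound 3 to compound 4 (0.23 log units; within the scatter), so on a double-bonded chain carbon bound to a double-bonded ring carbon, 3,5-dichlorophenyl and 3-bromophenyl cannot be told apart. For the compounds shown here, this is the first step read at this place, and a ring with two chlorine atoms holds the number as well as one with a single bromine. Nothing available here accounts for the step. Since the halogen and its count change together, neither can be read alone. As far as these compounds go, whether an amine or a carboxylic acid on this ring would hold the number also remains open.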